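From isopropyl to ethyl: an estimate for compound 4

The compounds below may be only part of what the source reports. "The series", "measured", "known", "first", "only" and "open" are said of these compounds alone.

Measured compounds in a functional assay on NZB5 cells (Homo sapiens) for inhibition, read by thymidine incorporation, with a stated time of 5 days; a higher number here means a weaker inhibitor, a lower number a stronger inhibitor:
- compound 1 `CN(C)c1ccc([N+](=O)[O-])cc1S(=O)(=O)N(C)/N=C/c1cnn2ccc(C#N)cc12`: 40 nM
- compound 2 `CN(/N=C/c1cnn2ccc(C#N)cc12)C(=O)c1cccc([N+](=O)[O-])c1`: 1800 nM
- compound 3 `CC(C)c1ccc([N+](=O)[O-])cc1S(=O)(=O)N(C)/N=C/c1cnn2ccc(C#N)cc12`: 180 nM

Compound 3 holds the middle place of the three. Its number is higher than that of compound 1 and lower than that of compound 2, and both gaps lie beyond the scatter.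

Compound 4 `CCc1ccc([N+](=O)[O-])cc1S(=O)(=O)N(C)/N=C/c1cnn2ccc(C#N)cc12` has not yet been measured in this assay. It differs from compound 3 by one change, isopropyl to ethyl: hydrogen in place of methyl on a saturated chain carbon bound to an aromatic carbon and a saturated chain carbon. This is hydrogen in place of methyl on a saturated chain carbon bound to an aromatic carbon and a saturated chain carbon.

Within the data shown here, only one measured step bears on this group, a 4.5-fold higher number from compound 1 to compound 3 (0.65 log units; beyond the scatter), and it is modest. That step replaces dimethylamino with isopropyl, so it does not measure a shortening of the chain directly. Only a small move towards a lower number is therefore expected, one that may not clear the scatter. The expected change is a 1.4-fold lower number from compound 3 to compound 4 (0.14 log units; within the scatter). For compound 4 the estimated value is 130 nM, with an expected range from 55 nM to 320 nM.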

Compound 4, half-maximal inhibitory concentration: 170 nM
Compound 4: middle estimate off by 1.3-fold (0.12 log units), on the low side; low and high end bracket the measured number.
By their numbers in this assay, from the lowest: compound 1; then compounds 4 and 3 (each within the scatter of the next); then compound 2.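

The new result shows that this aromatic carbon tolerates the loss of one methyl from the isopropyl group: in this assay, hydrogen in place of methyl on the saturated chain carbon gives a 1.1-fold lower number from compound 3 to compound 4 (0.02 log units; within the scatter) and leaves the two compounds indistinguishable. The ethyl and isopropyl groups therefore cannot be separated by this read-out. Ethyl in place of dimethylamino gives a 4.3-fold higher number from compound 1 to compound 4 (0.63 log units; beyond the scatter) and stands beside a 4.5-fold higher number from compound 1 to compound 3 (0.65 log units; beyond the scatter) as a second step beyond the scatter, so compound 1 keeps the lowest number of this set with either carbon chain as the comparison.

As far as these compounds go, whether a methyl group, a longer chain, or a primary amine on this aromatic carbon would move the number remains open. No measurement offered here accounts for the gap between dimethylamino and the two carbon chains.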